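Swapping a hydroxyphenyl for a pentylphenyl on a shared core

The source may report more compounds than this note shows. Statements on the series, on what has been measured and on what is new or still open speak of the compounds shown alone.

Of the compounds shown here, three have been tested in a functional assay on CFPAC-1 cells (Homo sapiens) for antiproliferative activity, read by MTT assay, with a stated time of 72 h; on this read-out lower numbers stand for stronger inhibition and higher numbers for weaker inhibition. Among the measured compounds shown here, compound 2 `O=C1O[C@H]([C@@H](O)Cn2cc(-c3cccc(O)c3)nn2)C(OCc2ccccc2)=C1OCc1ccccc1` is the one compound that gives a number, with 54100 nM. Compound 1 `COc1ccc(-c2cn(C/C=C3\OC(=O)C(OCc4ccccc4)=C3OCc3ccccc3)nn2)cc1` reaches only the limit of the assay, > 100000 nM. Compound 3 `CCCCCc1ccc(-c2cn(C/C=C3\OC(=O)C(OCc4ccccc4)=C3OCc3ccccc3)nn2)cc1` likewise stops at the limit, > 100000 nM. The step that the two limits leave unreadable from compound 1 to compound 3 therefore cannot be read, because of the limit of > 100000 nM in this assay, at which 2 of the 3 values shown sit.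

Compound 4 `CCCCCc1ccc(-c2cn(C[C@H](O)[C@H]3OC(=O)C(OCc4ccccc4)=C3OCc3ccccc3)nn2)cc1` shares the core of compound 2 and differs from it in one place: 4-pentylphenyl in place of 3-hydroxyphenyl on an aromatic carbon. For the measured compounds named here, no measured step follows this exact change on this core. Going by the values given here, the one related pair, compound 1 and compound 3, shows only that both sit at the limit. The nearest guide is compound 3, which carries the same 4-pentylphenyl group on a different core and gives > 100000 nM. On that basis compound 4 is expected to weaken, with the step of a 1.8-fold higher number from compound 2 to compound 4 (0.27 log units; within the scatter) carrying it toward the limit. The estimate for compound 4 is 100000 nM, with a range from 40000 nM to 300000 nM.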

Compound 4, half-maximal inhibitory concentration: 9890 nM
For compound 4 the middle estimate is 10-fold (1.00 log units) above the measured one; measured number outside the range, below it.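

In this assay, the exchange on this aromatic carbon of the five-membered ring gives a 5.5-fold lower number from compound 2 to compound 4 (0.74 log units; beyond the scatter), so activity on the shared core responds to the group at this position, and the hydrogen-bond donor of the 3-hydroxyphenyl is not needed to reach a measurable number. Compound 3 carries the same 4-pentylphenyl on a different core and is reported only as a limit, > 100000 nM. The group therefore does not yield a number on every core shown, and steps that touch this value cannot be read because of the limit: the limit of > 100000 nM in this assay, at which 2 of the 4 values shown sit.

The step changes both the substituent and its place on the phenyl ring, so the compounds shown do not separate these two effects. From the compounds shown here alone, whether a plain phenyl, a shorter chain such as ethyl or a longer chain such as octyl would fit this pattern remains open.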